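Thioester variant at the carbonyl of the thienyl dihydropyrimidinone series

The source may hold more compounds than are shown below. What is called first, only, known or untested is meant among the compounds shown, and "the series" means these compounds.

Of the compounds shown here, three of the shared core have been measured in an assay on membranes from HEK293 cells for displacement of a labelled ligand from adenosine receptor A2b (Homo sapiens), read by scintillation counting, with a stated time of 30 min, tested at 1 uM; a lower number here means less inhibition, a higher number more inhibition at the concentration tested (going by the name of the read-out). Compound 1 `CCOC(=O)C1=C(C)N(C)C(=O)NC1c1ccsc1` gives 53%. Compound 2 `CC1=C(C(=O)C2CC2)C(c2cccs2)NC(=O)N1` gives 1%. Compound 3 `CC1=C(C(=O)CC(C)C)C(c2cccs2)NC(=O)N1` gives 43%, the second highest of the three numbers; against compound 1 it lies within the scatter, against compound 2 it lies beyond it, with a number 42 percentage points higher from compound 2 to compound 3 (beyond the scatter).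

Compound 4 `CC1=C(C(=O)SC(C)C)C(c2cccs2)NC(=O)N1` is not yet measured. It differs from compound 3 by isopropylsulfanyl in place of isobutyl on a carbonyl carbon. Among the compounds with values here, the one measured step at the same carbonyl carbon, a number 42 percentage points higher from compound 2 to compound 3 (beyond the scatter), was large, so the group on that carbon moves the read-out strongly; no measured step, however, exchanges a carbon chain for a sulfur-linked one at this place, and the change of one acceptor is untested. Compound 4 is therefore expected near compound 3, with a wide band, estimated at 35% (range 5% to 65%), which would mean an expected step of a number 8 percentage points lower from compound 3 to compound 4 (within the scatter).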

Compound 4, a percentage reported as inhibition, at one concentration (the size of the read-out at that concentration, not a potency): 1%
Estimate against measurement, compound 4: 34 percentage points above, and the stated range ends above it.
By their numbers in this assay, from the lowest: compounds 2 and 4 (each within the scatter of the next); then compounds 3 and 1 (each within the scatter of the next).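

Isopropylsulfanyl in place of isobutyl on a carbonyl carbon gives a number 42 percentage points lower from compound 3 to compound 4 (beyond the scatter) in this assay, so the same number of heavy atoms at this place does not keep the read-out, and a change of one carbon to sulfur, with one added acceptor, comes with the whole of the loss. Isopropylsulfanyl in place of cyclopropyl gives no change at the digits printed from compound 2 to compound 4 (within the scatter), so among these three groups on the carbonyl carbon, only isobutyl holds the read-out clear of the low level. Nothing on hand gives a reason for this drop.

From the compounds shown here alone, it remains open whether the loss goes with the sulfur link or with the isopropyl group. An isopropoxy group or a longer sulfur-linked chain such as butylsulfanyl on the same carbonyl carbon would separate these two readings.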